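The source may hold more compounds than are shown below. What is called first, only, known or untested is meant among the compounds shown, and "the series" means these compounds.

Compound 1 `C[C@@H]1CN(CCCN(C(=O)Nc2ccc(F)c(C(F)(F)F)c2)[C@@H]2CC[C@]3(c4cnc(CN)s4)CC23)[C@@H](C)CN1` gives 19 nM in a functional assay for antagonist activity at melanin-concentrating hormone receptor 1 (Homo sapiens); a higher number here means a weaker inhibitor, a lower number a stronger inhibitor. Compound 2 `C[C@@H]1CN(CCCN(C(=O)Nc2cc(Cl)nc(Cl)c2)[C@@H]2CC[C@]3(c4cnc(CN)s4)CC23)[C@@H](C)CN1` gives 13.1 nM, the lowest of the two numbers, and the step of a 1.5-fold lower number from compound 1 to compound 2 (0.16 log units; within the scatter) came with 2,6-dichloropyridin-4-yl in place of 4-fluoro-3-(trifluoromethyl)phenyl on an amide-type nitrogen. Compound 3 `C[C@@H]1CN(CCCN(C(=O)Nc2cc(Cl)nc(Cl)c2)[C@H]2CC[C@]3(c4cnc(CN)s4)C[C@H]23)[C@@H](C)CN1` differs from compound 2 only in stereochemistry: the two compounds have the same atoms and bonds; at least one stereo element is drawn with a configuration in one of them and without one in the other: 2 of 5 stereo elements differ; a stereocentre at a saturated ring carbon is drawn R in compound 2 and S in compound 3; a stereocentre at a saturated ring carbon is drawn without a configuration in compound 2 and S in compound 3. Among the compounds with values here, no measured step concerns such a change, so nothing here tells its size or direction. For compound 3 a somewhat higher number is expected, a 3.1-fold higher number from compound 2 to compound 3 (0.48 log units; beyond the scatter), giving an estimate of 40 nM with a range from 8 nM to 300 nM.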

Compound 3, inhibition constant: 6.1 nM
Beside the measured number, compound 3's estimate is 6.6-fold (0.82 log units) above it, and the stated range ends above it.
By their numbers in this assay, from the lowest: compound 3; then compounds 2 and 1 (each within the scatter of the next).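

In this assay a change in drawn stereochemistry alone, with atoms and bonds unchanged, goes with a 2.1-fold lower number from compound 2 to compound 3 (0.33 log units; beyond the scatter) and so moves the number modestly beyond the scatter, which the earlier exchange of aromatic groups did not do. This shows that the arrangement at these saturated ring carbons matters even when the groups stay the same. How much of the step belongs to either ring carbon cannot be settled, because the comparison rests on a difference in drawing: the fact that one of compounds 2 and 3 is drawn with a defined configuration and the other without, at the place where they differ

Still open, going by these compounds, is whether the same configuration gives a similar change with the 4-fluoro-3-(trifluoromethyl)phenyl group of compound 1. Also open, on these data alone, is how it behaves with a plain phenyl group on that amide-type nitrogen.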